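The source may report more compounds than this note shows. Statements on the series, on what has been measured and on what is new or still open speak of the compounds shown alone.

Of the compounds shown here, two that share one core have so far been tested in an assay on a protein complex for inhibition of CDK8/Cyclin C (Homo sapiens), with a stated time of 1 h, tested at 10 uM; a higher number here means more inhibition at the concentration tested (going by the name of the read-out), a lower number less inhibition. Compound 1, `NNC(=O)CCc1ccncc1-c1ccc2ccccc2c1`, gives 102% in this assay. Compound 2, `O=C(COc1ccncc1-c1ccc2ccccc2c1)N1CCOCC1`, gives 9% in this assay, the lower of the two numbers, and its gap to compound 1 lies beyond the usual scatter of such measurements. Compound 3, `O=C(O)COc1ccncc1-c1ccc2ccccc2c1`, has not yet been measured. It differs from compound 2 in a single place: hydroxy in place of morpholin-4-yl on a carbonyl carbon. Among the measured compounds no pair differs in just one place, so there is no measured step that speaks directly to this kind of change, and the expectation rests on compound 2 alone. The step of a number 6 percentage points higher from compound 2 to compound 3 (within the scatter) is expected to be small, possibly a modest rise, and not beyond the scatter. Compound 3 is therefore expected to give about 15% in this assay, within a range from 0% to 45%.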

Compound 3, a percentage reported as inhibition, at one concentration (the size of the read-out at that concentration, not a potency): 16%
The estimate for compound 3 lay 1 percentage points below the measured number, within the range that was stated.
By their numbers in this assay, from the lowest: compounds 2 and 3 (each within the scatter of the next); then compound 1.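

In this assay, hydroxy in place of morpholin-4-yl on a carbonyl carbon gives a number 7 percentage points higher from compound 2 to compound 3 (within the scatter), so removing the six-membered ring leaves no readable change at this position. The larger change, carboxymethoxy in place of 2-(aminocarbamoyl)ethyl on an aromatic carbon, gives a number 86 percentage points lower from compound 1 to compound 3 (beyond the scatter), which shows that replacing the whole group on the shared core matters far more here than this exchange at the carbonyl carbon. Nothing available explains either step.

As far as these compounds go, it remains open whether a simple amine or a longer carbon chain on the carbonyl carbon would also leave the number unchanged. The step from compound 1 replaces the whole group at once, so it does not reveal which part of 2-(aminocarbamoyl)ethyl goes with the high number.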